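A Single Hydroxyl Shift on a Shared Core

The source may report more compounds than this note shows. Statements on the series, on what has been measured and on what is new or still open speak of the compounds shown alone.

Compound 1 `Oc1ccc(-c2cc(-c3cccc(O)c3)cc(-c3ccc(O)cc3)n2)cc1` gives in a functional assay on HCT-15 cells (Homo sapiens) for cytotoxicity, read by CCK-8 assay, with a stated time of 4 days (on this read-out higher numbers stand for weaker inhibition and lower numbers for stronger inhibition), the limit > 50000 nM.
Compound 2 `Oc1ccc(-c2cc(-c3ccccc3O)cc(-c3ccccc3O)n2)cc1` gives in this assay 8240 nM.

The reading for compound 1 is a limit of the assay rather than a number (the limit of > 50000 nM in this assay, at which 1 of the 2 values shown sits). Among the compounds with values here, compound 2 therefore holds the only real value shown. Compound 3 `Oc1ccc(-c2cc(-c3cccc(O)c3)cc(-c3ccccc3O)n2)cc1` differs from compound 2 by 3-hydroxyphenyl in place of 2-hydroxyphenyl on an aromatic carbon. Within the data shown here, no step between measured compounds exists. Compound 1 reaches only a limit of the assay. Because compound 2 gives 8240 nM, compound 3 is expected to lose potency in this assay, the step of a 3.0-fold higher number from compound 2 to compound 3 (0.48 log units; beyond the scatter) probably beyond the scatter. Compound 3 is estimated at 25000 nM, between 8000 nM and 60000 nM.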

Compound 3, half-maximal inhibitory concentration: > 50000 nM
Compound 3: no number, only a limit; the forecaster's own chance of this, stated with the estimate: 35%; middle value at least 2.0-fold (0.30 log units) away from the limit.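

In this assay, within the data shown here, moving the hydroxyl at the place opposite the ring nitrogen, with 3-hydroxyphenyl in place of 2-hydroxyphenyl, gives the first readable step, an at least 6.0-fold higher number from compound 2 to compound 3 (0.78 log units; beyond the scatter), so this change alone, with the same atoms joined differently, is enough to lose the measurable value. Compound 3 reaches only a limit of the assay: the limit of > 50000 nM in this assay, at which 2 of the 3 values shown sit. The step between compound 1 and compound 3 cannot be read, as both are limits.

From the compounds shown here alone, whether an amine or a methoxy group in place of this hydroxyl would keep a measurable value stays open.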